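The source may report more compounds than this note shows. Statements on the series, on what has been measured and on what is new or still open speak of the compounds shown alone.

Measured compounds:
- Compound 1 `CC(=O)OC[C@H]1CN(c2ccc(-n3cc(-c4ccccn4)cn3)c(F)c2)C(=O)O1`. In an ADME assay on HEK293-A cells (Homo sapiens) for cytotoxicity, read by MTT assay, with a stated time of 48 h (a lower number here means a stronger inhibitor, a higher number a weaker inhibitor), compound 1 gives > 400 ug/mL, which is a limit of the assay and not a number.
- Compound 2 `CCC(=O)NC[C@H]1CN(c2ccc(-n3cc(-c4ccccn4)cn3)c(F)c2)C(=O)O1`. In this assay compound 2 gives 389 ug/mL.
- Compound 3 `COC(=O)NC[C@H]1CN(c2ccc(-n3cc(-c4ccccn4)cn3)c(F)c2)C(=O)O1`. In this assay compound 3 gives 306 ug/mL.

Compound 3 holds the lowest of the two numbers in this assay; its nearest neighbour is compound 2, with a 1.3-fold lower number from compound 2 to compound 3 (0.10 log units; within the scatter). The other steps from the reference, an at least 1.0-fold lower number from compound 1 to compound 2 (0.01 log units; that floor lies within the scatter) and an at least 1.3-fold lower number from compound 1 to compound 3 (0.11 log units; that floor lies within the scatter), start from a limit of > 400 ug/mL in this assay, at which 1 of the 3 values shown sits, and carry floors that also sit within the scatter. So far no change to the side chain on the saturated ring carbon has moved the read-out beyond the noise.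

Compound 4 `CONC(=O)[C@H]1CN(c2ccc(-n3cc(-c4ccccn4)cn3)c(F)c2)C(=O)O1` differs from compound 3 by methoxycarbamoyl in place of ((methoxycarbonyl)amino)methyl on a saturated ring carbon. Going by the values given here, no measured step covers this exact change: the three measured steps exchange groups on a chain carbon or on a carbonyl carbon, and all stayed within the scatter. On that basis a step of no clear size is expected in this assay, and compound 4 is estimated at 320 ug/mL, with a range from 180 ug/mL to 420 ug/mL, so that the expected step of a 1.0-fold higher number from compound 3 to compound 4 (0.02 log units; within the scatter) lies within the scatter.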

Compound 4, half-maximal inhibitory concentration: > 400 ug/mL
Compound 4: only a limit was reported; the forecaster's own chance of this, stated with the estimate: 30%; at least 1.2-fold (0.09 log units) between middle value and limit.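

Going by these compounds alone, compound 4 is the first compound here to replace the whole group on the saturated ring carbon next to the ring oxygen: methoxycarbamoyl takes the place of the methyl-linked groups of compounds 1 to 3, rather than one end of such a group being exchanged. Even this wider change gives only floors, an at least 1.3-fold higher number from compound 3 to compound 4 (0.11 log units; that floor lies within the scatter) and an at least 1.0-fold higher number from compound 2 to compound 4 (0.01 log units; that floor lies within the scatter), so no step at this position is yet shown to lie beyond the scatter, and the step involving compound 1 cannot be read. In this assay compound 4 gives > 400 ug/mL, which is a limit of the assay and not a number, and the series now has a second compound at that limit: the limit of > 400 ug/mL in this assay, at which 2 of the 4 values shown sit.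

On these data alone, the true size of the steps to compound 4 stays open, so these data do not tell whether the methyl link matters in this assay. As far as these compounds go, it also remains open whether a free amine, a carboxylic acid or a longer chain on this ring carbon would give a step beyond the scatter.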